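A few compounds are considered here, and "the series" means these few. Any claim that something is new, unique, unknown or untested is made for them only; others in the source may bear on it.

Measured so far:
compound 1, `COc1ccc(F)cc1Nc1cc(NC(=O)Nc2c(Cl)cccc2Cl)ncn1` — 78%
compound 2, `COc1cc(NC(=O)Nc2cc(Nc3ccc(F)c(Cl)c3)ncn2)cc(OC)c1` — 53.1%

In a functional assay on HCC827 cells (Homo sapiens) for inhibition, read by MTT assay, with a stated time of 48 h, tested at 10 uM (a higher number here means more inhibition at the concentration tested (going by the name of the read-out), a lower number less inhibition), compound 1 gives 78%. In this assay compound 2 gives 53.1%, the lowest of the two numbers; the distance to compound 1 lies beyond the scatter of repeated measurements. Within the data shown here, compounds 1 and 2 differ from each other in more than one place, so no step between measured compounds is available that would isolate a single change.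

Compound 3, `COc1cc(NC(=O)Nc2cc(Nc3ccc(OC)c(I)c3)ncn2)cc(OC)c1`, has not yet been measured. It differs from compound 2 in one place: 3-iodo-4-methoxyphenyl in place of 3-chloro-4-fluorophenyl on a nitrogen on an aromatic ring

Among the measured compounds shown here, with no single-point step to go by, the expectation rests on compound 2 alone, whose value 53.1% is the only direct reference. The estimated step of a number 1.9 percentage points higher from compound 2 to compound 3 (within the scatter) is small and within the scatter, in no firm direction. The expected value for compound 3 in this assay is 55%, with a range from 30% to 78%.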

Compound 3, a percentage reported as inhibition, at one concentration (the size of the read-out at that concentration, not a potency): 61.7%
Compound 3: middle estimate off by 6.7 percentage points, on the low side; the measured number falls inside the stated range.
By their numbers in this assay, from the lowest: compounds 2 and 3 (each within the scatter of the next); then compound 1.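

In this assay, among these compounds, putting 3-iodo-4-methoxyphenyl in place of 3-chloro-4-fluorophenyl on a nitrogen on an aromatic ring gives a number 8.6 percentage points higher from compound 2 to compound 3 (within the scatter), the first single-place comparison. This position on the shared core therefore accepts an exchange of both substituents on the phenyl ring, with iodine and methoxy entering for chlorine and fluorine, without a difference that this read-out can separate from the scatter, even though the entering group carries a hydrogen-bond acceptor that the leaving group lacks. Nothing at hand accounts for how close the two numbers lie.

Because this is one exchange between two substituted phenyl groups, it leaves open how each substituent contributes on its own and whether a phenyl ring is needed on that nitrogen at all, a question that a group such as morpholine, a simple amine or a carboxylic acid-bearing ring would address. Compound 1 differs from compound 2 and compound 3 in more than one place, so what separates its number from theirs remains unassigned.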